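Shifting the Fluorine on the Pyridine of Compound 1

A few compounds are considered here, and "the series" means these few. Any claim that something is new, unique, unknown or untested is made for them only; others in the source may bear on it.

Compound 1, `OC(c1ncccc1F)C1(c2ccc(Cl)c(Cl)c2)CCC1`: 610 nM
Compound 2, `OC(c1ncccn1)C1(c2ccc(OC(F)(F)F)cc2)CCC1`: 1540 nM
Compound 3, `OC(c1ccccn1)C1(c2ccc(Cl)c(Cl)c2)COC1`: 7370 nM

All three were tested in an assay on HEK293 cells for antagonist activity at transient receptor potential cation channel subfamily V member 3 (Homo sapiens), read by FLIPR and calcium flux; on this read-out higher numbers stand for weaker inhibition and lower numbers for stronger inhibition. Compound 1 gives the lowest number of the three: compound 2 sits at a higher value, beyond the scatter, and compound 3 higher still. Compound 4, `OC(c1cc(F)ccn1)C1(c2ccc(Cl)c(Cl)c2)CCC1`, has not yet been measured. It differs from compound 1 in one place: 4-fluoropyridin-2-yl in place of 3-fluoropyridin-2-yl on a saturated chain carbon bound to an oxygen on a saturated carbon and a saturated ring carbon. The same atoms are joined differently; only the fluorine moves on the ring. For the measured compounds named here, no measured pair here shows such a move, so no step can be read from the data. The expectation is a change within the usual scatter, in either direction. Compound 4 is therefore expected to give 800 nM (range 250 nM to 2500 nM), a step of a 1.3-fold higher number from compound 1 to compound 4 (0.12 log units; within the scatter) that is expected to stay within the scatter.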

Compound 4, antagonist equilibrium constant: 640 nM
For compound 4 the middle estimate is 1.3-fold (0.10 log units) above the measured one, within the range that was stated.
By their numbers in this assay, from the lowest: compounds 1 and 4 (each within the scatter of the next); then compound 2; then compound 3.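

In this assay, for the compounds shown here, the change to 4-fluoropyridin-2-yl in place of 3-fluoropyridin-2-yl gives a 1.0-fold higher number from compound 1 to compound 4 (0.02 log units; within the scatter) and is the first comparison in this set that differs in only one place. On this saturated chain carbon, the two fluorine placements cannot be told apart by this read-out. No measurement shown here offers an explanation for this result.

Still open, going by these compounds, is whether a methoxy group or an amine in place of this fluorine would also stay within the scatter. On these data alone, the effect of the same fluorine move on other cores also remains unknown.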